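A few compounds are considered here, and "the series" means these few. Any claim that something is new, unique, unknown or untested is made for them only; others in the source may bear on it.

Three compounds sharing one core have numbers in a functional assay on HepG2 cells (Homo sapiens) for cytotoxicity, read by MTT assay, with a stated time of 48 h; on this read-out lower numbers stand for stronger inhibition and higher numbers for weaker inhibition. Compound 1 `Cc1ncc([N+](=O)[O-])n1CCSc1nnc(-c2ccccc2N)o1` gives 4500 nM, compound 2 `Cc1ncc([N+](=O)[O-])n1CCSc1nnc(-c2ccccc2F)o1` gives 3700 nM, and compound 3 `Cc1ncc([N+](=O)[O-])n1CCSc1nnc(-c2ccc(F)cc2)o1` gives 600 nM. Compound 3 holds the lowest number of the three, and its distance to each of the others lies beyond the scatter. The account now turns to compound 4 `Cc1ccc(-c2nnc(SCCn3c([N+](=O)[O-])cnc3C)o2)c(O)c1`, not yet measured, which differs from compound 3 as follows: 2-hydroxy-4-methylphenyl in place of 4-fluorophenyl on an aromatic carbon. In words, 2-hydroxy-4-methylphenyl stands in place of 4-fluorophenyl on an aromatic carbon.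

Among the compounds with values here, no measured step introduces a hydroxy or a methyl group, so the evidence is indirect. The nearest guides are the steps that leave 2-aminophenyl and 2-fluorophenyl for 4-fluorophenyl: a 7.5-fold lower number from compound 1 to compound 3 (0.88 log units; beyond the scatter) and a 6.2-fold lower number from compound 2 to compound 3 (0.79 log units; beyond the scatter), both modest. The step of a 1.2-fold lower number from compound 1 to compound 2 (0.09 log units; within the scatter) lies within the scatter. The entering group also carries a substituent in its 2 position, so compound 4 is expected to sit nearer compound 2, at 3700 nM, than compound 3 does. A modest step to a higher number is therefore expected in this assay. The expected step is a 3.7-fold higher number from compound 3 to compound 4 (0.56 log units; beyond the scatter). For compound 4 the estimated value is 2200 nM, with an expected range from 700 nM to 6500 nM.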

Compound 4, half-maximal inhibitory concentration: 16600 nM
Compound 4: the middle estimate sits 7.5-fold (0.88 log units) below what was measured; measured number above the stated range.
By their numbers in this assay, from the lowest: compound 3; then compounds 2 and 1 (each within the scatter of the next); then compound 4.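

In this assay, 2-hydroxy-4-methylphenyl gives the highest number of the four compounds, with a 28-fold higher number from compound 3 to compound 4 (1.44 log units; beyond the scatter) when it stands in place of 4-fluorophenyl. The gap does not depend on the comparison with 4-fluorophenyl alone, as the number also rises against the other two groups: a 4.5-fold higher number from compound 2 to compound 4 (0.65 log units; beyond the scatter) and a 3.7-fold higher number from compound 1 to compound 4 (0.57 log units; beyond the scatter). Within the data shown here, compounds 1 and 2 lay within the scatter of each other, whereas compound 4 shows that phenyl groups substituted at this place on the shared core do not all read alike, and that this aromatic carbon tolerates changes with a wider spread of numbers than the earlier compounds revealed. Nothing available explains why the number rises with this group.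

The entering group brings a hydroxy and a methyl together, so the compounds shown leave open how much of the step belongs to each. As far as these compounds go, a plain 2-hydroxyphenyl, a 4-methylphenyl or a 2-methoxyphenyl group at the same place would separate these contributions, and where each would fall relative to compound 3 and compound 4 remains open.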